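Adding One Methyl to Compound 3

A few compounds are considered here, and "the series" means these few. Any claim that something is new, unique, unknown or untested is made for them only; others in the source may bear on it.

In a functional assay on MT4 cells (Homo sapiens) for cytotoxicity (a higher number here means that more compound is tolerated, a lower number that less compound is tolerated), compound 2 `CCC(C)Sc1nc(O)c(C)c(Cc2c(F)cccc2F)n1` gives 200000 nM and compound 3 `CC(C)Sc1nc(O)cc(C(C)c2c(Cl)cccc2Cl)n1` gives 117000 nM, so these two values lie within the usual scatter of each other. Compound 1 `Cc1c(Cc2c(F)cccc2F)nc(SC(C)C)[nH]c1=O` gives only a limit, > 200000 nM. Compound 4 `CCC(c1cc(O)nc(SC(C)C)n1)c1c(Cl)cccc1Cl` is the next to consider, and it differs from compound 3 by one small change: methyl in place of hydrogen on a saturated chain carbon, two bonds along the chain from two aromatic carbons, methyl in place of hydrogen on a saturated chain carbon. For the measured compounds named here, no two measured compounds differ in only one place, so the data set no size for this change. The expectation therefore starts from compound 3 at 117000 nM. Expected is a 1.2-fold lower number from compound 3 to compound 4 (0.07 log units; within the scatter), a change no larger than the scatter. Compound 4 is estimated at 100000 nM, with an expected range from 45000 nM to 200000 nM.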

Compound 4, half-maximal cytotoxic concentration: > 200000 nM
Compound 4 was reported as a limit (the forecaster's own chance of this, stated with the estimate: 15%); middle value at least 2.0-fold (0.30 log units) from the limit.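

For the compounds shown here, on this saturated chain carbon, methyl in place of hydrogen gives an at least 1.7-fold higher number from compound 3 to compound 4 (0.23 log units; that floor lies within the scatter) in this assay as the first step in this set that changes only one place. Compound 4 gives > 200000 nM as a limit of the assay and not a number. The step is therefore only a floor on the size of this change, and its true size cannot be read: the limit of > 200000 nM in this assay, at which 2 of the 4 values shown sit.

The compounds shown leave open how the number would respond to a longer chain, such as propyl, on this carbon. They also leave open the effect of an amine there.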